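Swapping a chlorine-bearing ring for a methyl-bearing one

The compounds below may be only part of what the source reports. "The series", "measured", "known", "first", "only" and "open" are said of these compounds alone.

Measured so far:
compound 1 `COc1cc2ncnc(NNC(=S)NC(=O)c3ccccc3Cl)c2cc1OC`: 3560 nM
compound 2 `O=C(NC(=S)NNc1ncnc2ccccc12)c1ccc(Cl)cc1`: 3940 nM

In a functional assay on KB cells (Homo sapiens) for cytotoxicity, read by MTT assay, with a stated time of 72 h (a lower number here means a stronger inhibitor, a higher number a weaker inhibitor), compound 2 gives 3940 nM, and compound 1 gives 3560 nM, two numbers that cannot be told apart within the usual scatter. Compound 3 `Cc1ccccc1C(=O)NC(=S)NNc1ncnc2ccccc12` has not been measured. It differs from compound 2 by 2-methylphenyl in place of 4-chlorophenyl on a carbonyl carbon. For the measured compounds named here, no measured pair shows what this kind of exchange does here, so no shift beyond the scatter is expected in this assay, in either direction. Compound 3 is therefore estimated at 4000 nM, with a likely range from 1800 nM to 9000 nM, an expected step of a 1.0-fold higher number from compound 2 to compound 3 (0.01 log units; within the scatter).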

Compound 3, half-maximal inhibitory concentration: 2770 nM
Compound 3: the middle estimate sits 1.4-fold (0.16 log units) above what was measured, and the stated range covers the measured number.
By their numbers in this assay, from the lowest: compounds 3, 1 and 2 (each within the scatter of the next).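

In this assay, the exchange of 4-chlorophenyl for 2-methylphenyl on the carbonyl carbon gives a 1.4-fold lower number from compound 2 to compound 3 (0.15 log units; within the scatter). This first measured pair for the position therefore shows that this one exchange of ring leaves the cytotoxicity reading indistinguishable from that of compound 2. Nothing measured here offers an explanation for this result. Still open, on these data alone, is whether a group of another kind at this place, such as a longer carbon chain or a phenyl ring carrying a carboxylic acid or an amine, would move the number beyond the scatter.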